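The source may hold more compounds than are shown below. What is called first, only, known or untested is meant among the compounds shown, and "the series" means these compounds.

Compound 1 `CCCCCCCCCCSC[C@H](NC(C)=O)C(=O)CCl` is the shorter of the two measured chloromethyl ketones. In a functional assay on MOLT-3 cells (Homo sapiens) (a higher number here means a weaker inhibitor, a lower number a stronger inhibitor), compound 1 gives 3400 nM. Compound 2 `CCCCCCCCCCCCSC[C@H](NC(C)=O)C(=O)CCl` carries a longer chain, and in this assay compound 2 gives 2300 nM. The step between them, a 1.5-fold lower number from compound 1 to compound 2 (0.17 log units; within the scatter), is too small to separate the two compounds, so compound 2 cannot be called different from compound 1 on the numbers shown.

Compound 3 `CCCCCCCCCCCCCCCSC[C@H](NC(C)=O)C(=O)CCl` extends the chain once more. The change is propyl in place of hydrogen on a saturated chain carbon, ten or more bonds along the chain from a sulfur. Among the compounds with values here, only one measured step bears on this kind of change, the chain extension a 1.5-fold lower number from compound 1 to compound 2 (0.17 log units; within the scatter), and it stayed within the scatter. A further extension is therefore expected to move the number little, perhaps slightly downward, but not beyond the scatter. Compound 3 is expected to give about 1800 nM, within a range from 800 nM to 4000 nM. This corresponds to an expected step of a 1.3-fold lower number from compound 2 to compound 3 (0.11 log units; within the scatter).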

Compound 3, half-maximal inhibitory concentration: 8600 nM
Estimate against measurement, compound 3: 4.8-fold (0.68 log units) below; measured number outside the range, above it.
By their numbers in this assay, from the lowest: compounds 2 and 1 (each within the scatter of the next); then compound 3.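

In this assay, within the data shown here, the chain is not free to grow without limit: propyl in place of hydrogen on a saturated chain carbon, ten or more bonds along the chain from a sulfur, gives a 3.7-fold higher number from compound 2 to compound 3 (0.57 log units; beyond the scatter) and is the first step here to pass the scatter. The longest chain also separates from the shortest, with a 2.5-fold higher number from compound 1 to compound 3 (0.40 log units; beyond the scatter) on record, so across these three compounds the number does not keep falling as the chain grows, and compound 3 has the highest number of the three. No measurement at hand gives a reason for this rise.

Going by these compounds, whether the number climbs gradually or abruptly at chain lengths between those of compound 2 and compound 3 stays open, as does the effect of a still longer chain. A chain ending in an amine or a carboxylic acid could show whether what sits at the chain's end matters as well as its length.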